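Flipping the ring stereocentre of compound 3

The source may report more compounds than this note shows. Statements on the series, on what has been measured and on what is new or still open speak of the compounds shown alone.

Compound 3 `NC(=O)[C@@H](CCC(F)(F)F)N(C[C@@H]1CCO1)S(=O)(=O)c1ccc(Cl)cc1` gives the lowest number of the three measured compounds in an in vitro ADME assay on microsomes from liver (Homo sapiens) for metabolic stability, read by HPLC (a higher number here means faster removal of the compound, a lower number slower removal), namely 62.1 mL/min/kg. Compound 1 `NC(=O)[C@@H](CCC(F)(F)F)N(C[C@@H]1CCCOC1)S(=O)(=O)c1ccc(Cl)cc1` gives 136 mL/min/kg in this assay, and compound 2 `NC(=O)[C@@H](CCC(F)(F)F)N(C[C@H]1CCCO1)S(=O)(=O)c1ccc(Cl)cc1` gives 231 mL/min/kg. Compound 3 sits a modest step below both of them: a 2.2-fold lower number from compound 1 to compound 3 (0.34 log units; beyond the scatter) and a 3.7-fold lower number from compound 2 to compound 3 (0.57 log units; beyond the scatter), while a 1.7-fold higher number from compound 1 to compound 2 (0.23 log units; within the scatter). Compound 4 `NC(=O)[C@@H](CCC(F)(F)F)N(C[C@H]1CCO1)S(=O)(=O)c1ccc(Cl)cc1` is the partner of compound 3 with the two compounds have the same atoms and bonds and differ only in configuration as drawn: 1 of 2 stereo elements differ; a stereocentre at a saturated ring carbon is drawn S in compound 3 and R in compound 4. Going by the values given here, none of the measured steps involves such a change; each of them swaps one saturated oxygen ring for another of a different size. So nothing here shows how this assay responds to a flip in configuration at the ring carbon, and the expectation rests on compound 3 alone. The expected step is a 1.0-fold lower number from compound 3 to compound 4 (0.00 log units; within the scatter), which lies within the scatter and has no direction to it. Compound 4 is expected to give 62 mL/min/kg, with a range from 35 mL/min/kg to 110 mL/min/kg.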

Compound 4, clearance: 63.8 mL/min/kg
Beside the measured number, compound 4's estimate is 1.0-fold (0.01 log units) below it; the range from low to high includes it.
By their numbers in this assay, from the lowest: compounds 3 and 4 (each within the scatter of the next); then compounds 1 and 2 (each within the scatter of the next).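

In this assay, the two configurations at the ring carbon cannot be told apart, with a 1.0-fold higher number from compound 3 to compound 4 (0.01 log units; within the scatter). The gap to the larger oxygen rings seen with compound 3 therefore also holds for the other configuration of the oxetan-2-yl group, with a 3.6-fold lower number from compound 2 to compound 4 (0.56 log units; beyond the scatter) and a 2.1-fold lower number from compound 1 to compound 4 (0.33 log units; beyond the scatter). The pair gives a clean reading of this stereocentre because nothing else separates the two compounds: the fact that compounds 3 and 4 differ only in the configuration as drawn

From the compounds shown here alone, whether the oxan-3-yl and oxolan-2-yl compounds would respond as little to a flip at their ring carbon remains open, as does the effect of a flip at the second stereocentre, which is the same in compound 3 and compound 4. Also open, going by these compounds, is how an amine or a longer chain in place of the oxetan-2-yl group would fare in this assay.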